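A methyl in place of hydrogen on compound 2

The source may report more compounds than this note shows. Statements on the series, on what has been measured and on what is new or still open speak of the compounds shown alone.

Compound 1 (`Clc1ccc(-c2cc(-c3cccs3)nc(-c3cccs3)c2)o1`) gives 54800 nM
Compound 2 (`Cc1ccsc1-c1cc(-c2ccco2)cc(-c2cccs2)n1`) gives 59600 nM

In a functional assay on MDA-MB-231 cells (Homo sapiens) for cytotoxicity, with a stated time of 3 days (a lower number here means a stronger inhibitor, a higher number a weaker inhibitor), compound 2 stands at 59600 nM and lies within the usual scatter of compound 1 at 54800 nM so the two cannot be told apart on these numbers.

Compound 3 (`Cc1ccsc1-c1cc(-c2ccco2)cc(-c2sccc2C)n1`) has not yet been measured. It differs from compound 2 in one place, thiophen-2-yl to 3-methylthiophen-2-yl: methyl in place of hydrogen on an aromatic carbon. The change sits on a five-membered aromatic ring with 1 sulfur, next to the ring atom that bears a large group. Compound 3 therefore carries the 3-methylthiophen-2-yl group twice, where compound 2 carries it once.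

Within the data shown here, no pair of measured compounds shows what such a change does, so the expectation rests on the two closely spaced values alone. No step beyond the scatter is expected in this assay in either direction. The estimate amounts to a 1.2-fold lower number from compound 2 to compound 3 (0.08 log units; within the scatter) (expected to stay within the scatter). Compound 3 is expected at about 50000 nM (estimated range 22000 nM to 100000 nM).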

Compound 3, half-maximal inhibitory concentration: 38300 nM
Estimate against measurement, compound 3: 1.3-fold (0.12 log units) above; the measured number falls inside the stated range.
By their numbers in this assay, from the lowest: compounds 3, 1 and 2 (each within the scatter of the next).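

In this assay, among these compounds, the methyl in place of hydrogen gives a 1.6-fold lower number from compound 2 to compound 3 (0.19 log units; within the scatter) and so provides the first direct reading of a single change. The step shows that, on this aromatic carbon of the five-membered aromatic ring with 1 sulfur, changing thiophen-2-yl to 3-methylthiophen-2-yl produces no difference that can be told from the scatter, even though compound 3 then carries that group twice. Nothing shown gives a reason for this outcome, and a single step within the scatter cannot by itself supply one.

The compounds shown leave open whether this position would respond in the same way to anything other than methyl, such as an ethyl group, a methoxy group, an amine or a carboxylic acid. They also leave open whether a methyl on another carbon of the same ring, or on the furan ring of compound 3, would likewise stay within the scatter.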